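Mirror-Image Stereocentre at the Limit of the Assay

The compounds below may be only part of what the source reports. "The series", "measured", "known", "first", "only" and "open" are said of these compounds alone.

In a functional assay on CCRF-CEM cells (Homo sapiens) for cytotoxicity (a higher number here means a weaker inhibitor, a lower number a stronger inhibitor), compound 1 `Cc1cn([C@H]2CC(F)(F)[C@H](CO)O2)c(=O)[nH]c1=O` gives > 100000 nM, which is a limit and not a number. Compound 2 `Nc1ccn([C@H]2C=C(F)[C@H](CO)O2)c(=O)n1` gives > 100000 nM, also a limit. Compound 3 `Nc1ncnc2c1ncn2[C@@H]1CC(F)(F)[C@H](CO)O1` gives > 100000 nM, again a limit. So compound 3 stands with the others at the limit of > 100000 nM in this assay, at which 3 of the 3 values shown sit.

Compound 4 `Nc1ncnc2c1ncn2[C@H]1CC(F)(F)[C@H](CO)O1` keeps the same atoms and bonds as compound 3: the two compounds have the same atoms and bonds and differ only in configuration as drawn: 1 of 2 stereo elements differ; a stereocentre at a saturated ring carbon is drawn S in compound 3 and R in compound 4. A stereocentre at a saturated ring carbon is drawn S in compound 3 and R in compound 4. For the measured compounds named here, no measured pair here shows what such a change does, so no step beyond the usual scatter is expected. The expected step is a number no higher from compound 3 to compound 4 (the limit leaves the size open). Compound 4 is estimated at 100000 nM, within an expected range of 40000 nM to 150000 nM.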

Compound 4, half-maximal inhibitory concentration: > 100000 nM
Compound 4 gave a limit, no number (the forecaster's own chance of this, stated with the estimate: 85%); the middle value sits exactly at the limit.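

For the compounds shown here, compound 3 and compound 4 both give only a limit, so no step between them can be read. Left open is whether this change in configuration affects potency in this assay at all.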